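A few compounds are considered here, and "the series" means these few. Any claim that something is new, unique, unknown or untested is made for them only; others in the source may bear on it.

Compound 2, with the structure `C=C1C(=O)[C@]23C[C@@]1(O)CC[C@H]2c1ccc(O)c(C)c1[C@@H]3Cn1cc(-c2ccccn2)nn1`, and compound 1, with the structure `C=C1C(=O)[C@]23C[C@@]1(O)CC[C@H]2c1ccc(OS(=O)(=O)c2ccc(C)cc2)c(C)c1[C@@H]3Cn1cc(-c2ccccn2)nn1`, share one core and differ at a single site. In a functional assay on SMMC-7721 cells (Homo sapiens) for cytotoxicity, read by MTT assay, with a stated time of 4 days (on this read-out higher numbers stand for weaker inhibition and lower numbers for stronger inhibition), compound 2 gives 1270 nM. In this assay compound 1 gives 2830 nM. The change between them is (4-methylphenyl)sulfonyl in place of hydrogen on an oxygen on an aromatic ring, and it brings a 2.2-fold higher number from compound 2 to compound 1 (0.35 log units; beyond the scatter).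

Compound 3, with the structure `Cc1ccc(-c2cn(C[C@H]3c4c(ccc(O)c4C)[C@@H]4CC[C@@]5(C)C[C@]43CC5=O)nn2)cc1`, is built on a different core; how the two cores differ is not broken down here. In this assay compound 3 reaches only a limit of the method, > 20000 nM, and no number is reported for it. Compound 4, with the structure `Cc1ccc(-c2cn(C[C@H]3c4c(ccc(OS(=O)(=O)c5ccc(C)cc5)c4C)[C@@H]4CC[C@@]5(C)C[C@]43CC5=O)nn2)cc1`, carries the same change relative to compound 3, namely ((4-methylphenyl)sulfonyl in place of hydrogen on an oxygen on an aromatic ring), at the same kind of place and with the same surroundings as in the pair of compound 2 and compound 1.

For compound 4 the expectation rests on two points: compound 3 already sits at the limit of > 20000 nM in this assay, at which 1 of the 3 values shown sits, and the same change weakened inhibition between compound 2 and compound 1. Compound 4 is therefore expected to give 40000 nM, a step that the limit leaves unreadable from compound 3 to compound 4, and most likely the assay will again report only a limit.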

Compound 4, half-maximal inhibitory concentration: > 20000 nM
Compound 4: no number, only a limit; the forecaster's own chance of this, stated with the estimate: 85%; the middle value is on the limit's open side.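

Compound 4, like compound 3, gives no number but only a limit of the method, so no step from compound 3 to compound 4 can be read: the limit of > 20000 nM in this assay, at which 2 of the 4 values shown sit.

The compounds shown leave open whether (4-methylphenyl)sulfonyl in place of hydrogen changes inhibition at all on the core of compound 3, as it does on the core of compound 2.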